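Methyl homologation of a dinitrile series: cytotoxicity notes

The compounds below may be only part of what the source reports. "The series", "measured", "known", "first", "only" and "open" are said of these compounds alone.

Measured compounds and their values in a functional assay on HepG2 cells (Homo sapiens) for cytotoxicity, read by MTT assay, with a stated time of 48 h; a lower number here means a stronger inhibitor, a higher number a weaker inhibitor:
compound 1 `CC(c1nccs1)C(C#N)C#N` — compound 1 gives > 120000 nM, a limit of the assay.
compound 2 `N#CC(C#N)Cc1nccs1` — compound 2 gives > 120000 nM, a limit of the assay.
compound 3 `[O-][S+](CCC(F)=C(F)F)c1nccs1` — compound 3 gives > 120000 nM, a limit of the assay.

Compound 1 stands only at a limit in this assay; no number is available for it, and the same holds for compound 2 and compound 3. Among the measured compounds shown here, the one single-point step among the measured compounds, a step that the two limits leave unreadable from compound 1 to compound 2, cannot be read, since both ends are limits. The evidence therefore reduces to the limit of > 120000 nM in this assay, at which 3 of the 3 values shown sit.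

The unmeasured compound 4 `CC(C)(c1nccs1)C(C#N)C#N` differs from compound 1 by methyl in place of hydrogen on a saturated chain carbon bound to an aromatic carbon and two saturated chain carbons. For the measured compounds named here, no measured step bears on this change in a readable way, and the step from compound 1 to compound 2, which alters the same chain carbon, is itself unreadable. With every value in the series sitting at the limit, as in the limit of > 120000 nM in this assay, at which 3 of the 3 values shown sit, no step beyond the scatter is expected in this assay in either direction.

Compound 4 is therefore expected to reach only the limit again, with an estimated value of 150000 nM, ranging from 60000 nM to 400000 nM. The step that this estimate means, a step that the limit leaves unreadable from compound 1 to compound 4, is expected to lie within the scatter.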

Compound 4, half-maximal inhibitory concentration: > 120000 nM
Compound 4: no number, only a limit; the forecaster's own chance of this, stated with the estimate: 85%; the middle value does not contradict the limit.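

In this assay, among the compounds shown here, compound 4 stands only at a limit of the assay, as compound 1 does, so no step between these two compounds can be read. The compounds shown leave open what value any of them would give as a number, and whether any change to the shared core would yield one: the limit of > 120000 nM in this assay, at which 4 of the 4 values shown sit.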